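Neopentyl in place of tert-butyl in compound 4

The source may hold more compounds than are shown below. What is called first, only, known or untested is meant among the compounds shown, and "the series" means these compounds.

- compound 1 `COc1cc2ncnc(-n3nc(-c4ccccn4)nc3N)c2cc1[N+](=O)[O-]`: 2000 nM
- compound 2 `COc1cc2ncnc(-n3ncc(-c4ccccn4)c3N)c2cc1OC`: 1000 nM
- compound 3 `COc1cc2ncnc(-n3nc(-c4ccccn4)nc3N)c2cc1OCCCNC(=O)OC(C)(C)C`: 2000 nM

In a physicochemical assay for solubility, in phosphate buffer, with a stated time of 18 h, at pH 7.4 (on this read-out higher numbers stand for higher solubility and lower numbers for lower solubility), compound 3 gives 2000 nM, the same number as compound 1, and compound 2 at 1000 nM lies within the scatter of it. Compound 4 `COc1cc2ncnc(-n3nc(-c4ccccn4)nc3N)c2cc1OCCCNC(=O)OCC(C)(C)C` carries neopentyl in place of tert-butyl on an oxygen next to a carbonyl group. Among the measured compounds shown here, the one measured step that bears on this is no change at the digits printed from compound 1 to compound 3 (within the scatter), where 3-((tert-butoxycarbonyl)amino)propoxy took the place of nitro on an aromatic carbon. For the measured compounds named here, no measured step alters the tert-butyl itself. On that evidence, the estimated move, a 1.3-fold lower number from compound 3 to compound 4 (0.12 log units; within the scatter), is expected to stay within the scatter in this assay. The expected value for compound 4 is 1500 nM, with an estimated range of 700 nM to 3000 nM.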

Compound 4, solubility: 200 nM
The estimate for compound 4 lay 7.5-fold (0.88 log units) above the measured number; measured number below the stated range.
By their numbers in this assay, from the lowest: compound 4; then compounds 2, 1 and 3 (each within the scatter of the next).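

In this assay, neopentyl in place of tert-butyl on an oxygen next to a carbonyl group gives a 10-fold lower number from compound 3 to compound 4 (1.00 log units; beyond the scatter). The earlier step, with no change at the digits printed from compound 1 to compound 3 (within the scatter), gave no sign that this read-out responds to the chain, yet this change from 4 to 5 heavy atoms, with no ring, donor, acceptor or charge involved, moves the number beyond the scatter. No measurement here accounts for the drop.

Open, going by these compounds, is how other groups on this oxygen would compare, such as ethyl or a longer chain. Also open, on these data alone, is the result for a plain amine in place of (tert-butoxycarbonyl)amino.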